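The compounds below may be only part of what the source reports. "The series", "measured", "known", "first", "only" and "open" are said of these compounds alone.

Measured so far in an ADME assay on microsomes from liver (Homo sapiens) for metabolic stability; on this read-out higher numbers stand for a longer-lived compound and lower numbers for a shorter-lived compound:
compound 1 `CC(C)[C@H](C[C@H]1CCNC1=O)c1ccc(-c2ccc3cccc(F)c3c2)[nH]c1=O` gives 0.257 h
compound 2 `CC(C)C(/C=C1\CCNC1=O)c1ccc(-c2ccc3cccc(F)c3c2)[nH]c1=O` gives 0.713 h
compound 3 `CC(C)C(c1ccc(-c2ccc3cccc(F)c3c2)[nH]c1=O)N1CCN/C1=N\C#N` gives 0.632 h

On this assay compound 3 stands second highest of the three; compound 2 lies within the scatter of it, compound 1 beyond the scatter below it. Compound 4 is `CC(C)C(c1cnc(N)s1)c1ccc(-c2ccc3cccc(F)c3c2)[nH]c1=O`. Change from compound 3: a group of 6 heavy atoms (3 carbon, 2 nitrogen, 1 sulfur; one five-membered aromatic ring with 2 hetero atoms) in place of a group of 8 heavy atoms (4 carbon, 4 nitrogen; one five-membered non-aromatic ring with 2 hetero atoms), on a saturated chain carbon bound to an aromatic carbon and a saturated chain carbon. Within the data shown here, the only measured step at the same place, a 1.1-fold lower number from compound 2 to compound 3 (0.05 log units; within the scatter), stayed within the scatter, though there one five-membered non-aromatic ring gave way to another rather than to an aromatic one. Among the measured compounds shown here, compound 1, the only value beyond the scatter from compound 3, is not joined to it by a one-place step and so gives no guide. No step beyond the scatter is expected in this assay, in either direction. The estimate for compound 4 is 0.55 h, range 0.25 h to 1.2 h. That expected step is a 1.1-fold lower number from compound 3 to compound 4 (0.06 log units; within the scatter).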

Compound 4, half-life: 0.178 h
Estimate against measurement, compound 4: 3.1-fold (0.49 log units) above, outside the stated range (below it).
By their numbers in this assay, from the lowest: compounds 4 and 1 (each within the scatter of the next); then compounds 3 and 2 (each within the scatter of the next).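

In this assay the group on this saturated chain carbon now matters beyond the scatter: 2-amino-1,3-thiazol-5-yl gives a 3.6-fold lower number from compound 3 to compound 4 (0.55 log units; beyond the scatter) and a 4.0-fold lower number from compound 2 to compound 4 (0.60 log units; beyond the scatter). The exchange of one five-membered non-aromatic ring for the other had given only a 1.1-fold lower number from compound 2 to compound 3 (0.05 log units; within the scatter). No measurement at hand accounts for the lower number.

Still open, from the compounds shown here alone, is whether the lower number goes with the aromatic ring itself or with its amine. A plain thiazol-5-yl or a phenyl group at this place would separate the two.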